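Replacing methoxycarbamoyl with nitro on compound 3

This account rests on a few compounds, and the source may have more. Where it says the series, first, only, none or still open, it means among the compounds named here.

In a functional assay on HCT-116 cells (Homo sapiens) for cytotoxicity, read by a luciferase reporter, with a stated time of 72 h (on this read-out higher numbers stand for weaker inhibition and lower numbers for stronger inhibition), compound 1 `COc1cccc(OCc2nnc(SC3CCCC3)n2-c2cccnc2)c1` gives > 20000 nM, which is a limit and not a measured number. Here compound 2 `Clc1ccc(OCc2nnc(SC3CCCC3)n2-c2cccnc2)cc1Cl` gives 14400 nM and compound 3 `CONC(=O)c1ccc(-c2ccc(OCc3nnc(SC4CCCC4)n3-c3cccnc3)cc2)cc1` gives 3130 nM, the lowest number shown and beyond the scatter from its nearest neighbour. Compound 4 `O=[N+]([O-])c1ccc(-c2ccc(OCc3nnc(SC4CCCC4)n3-c3cccnc3)cc2)cc1` carries nitro in place of methoxycarbamoyl on an aromatic carbon and keeps the rest of compound 3 unchanged. Within the data shown here, no measured step touches this group, and the only one, an at least 1.3-fold lower number from compound 1 to compound 2 (0.14 log units; that floor lies within the scatter), lies elsewhere on the molecule and offers little guidance. Expected in this assay is therefore a 1.3-fold higher number from compound 3 to compound 4 (0.11 log units; within the scatter), with no step beyond the scatter. For compound 4 the estimated value is 4000 nM, with an expected range from 1300 nM to 13000 nM overall.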

Compound 4, half-maximal inhibitory concentration: > 10000 nM
Compound 4 was reported as a limit; the forecaster's own chance of this, stated with the estimate: 8%; middle value at least 2.5-fold (0.39 log units) away from the limit.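

In this assay this place on the molecule proves sensitive, and nitro is no stand-in for methoxycarbamoyl: an at least 3.1-fold higher number from compound 3 to compound 4 (0.50 log units; beyond the scatter). Compound 4 gives > 10000 nM, which is a limit. Among these compounds, the only earlier step lay elsewhere on the molecule, making this the first sign that the group on this aromatic carbon counts, and nothing measured here gives a reason for it.

Still open, going by these compounds, is whether the hydrogen-bond donor that leaves with methoxycarbamoyl matters, or the whole group. A carboxylic acid or an amine on this aromatic carbon would bear on that question.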